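The source may hold more compounds than are shown below. What is called first, only, known or untested is meant among the compounds shown, and "the series" means these compounds.

Compound 1 `CCCCSc1nc(N)nc2c1ncn2/C=C1/CC1(CO)CO` in an ADME assay on MOLT-3 cells (Homo sapiens) for cytotoxicity, with a stated time of 7 days (a lower number here means that less compound is tolerated, a higher number that more compound is tolerated), gives > 20000 nM, which is a limit of the assay and not a number.
Compound 2 `CCCCCCCCSc1nc(N)nc2c1ncn2/C=C1/CC1(CO)CO` gives > 20000 nM, again a limit rather than a number.
Compound 3 `Nc1nc(NC2CCCC2)c2ncn(/C=C3/CC3(CO)CO)c2n1` gives > 20000 nM, also a limit rather than a number.

In this assay there is thus no readable number among the three measured compounds; all of them sit at the limit of > 20000 nM in this assay, at which 3 of the 3 values shown sit. The step that the two limits leave unreadable from compound 1 to compound 2 cannot be sized, and the same holds for a step that the two limits leave unreadable from compound 1 to compound 3 and for a step that the two limits leave unreadable from compound 2 to compound 3. Compound 3 therefore stands exactly where compound 1 and compound 2 stand, at the limit, and nothing in the data separates it from either of them.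

Compound 4 `CSc1nc(N)nc2c1ncn2/C=C1/CC1(CO)CO` has not yet been measured. It differs from compound 3 in one place: methylsulfanyl in place of cyclopentylamino on an aromatic carbon. The measured steps that bear on this change are a step that the two limits leave unreadable from compound 1 to compound 3 and a step that the two limits leave unreadable from compound 2 to compound 3, which exchange an alkylsulfanyl group for cyclopentylamino on the same aromatic carbon, in the opposite direction; both are unreadable. No size can be drawn from them, so no step beyond the scatter in either direction is expected. Compound 4 is expected to give about 30000 nM, within a range from 15000 nM to 100000 nM, most probably reported once more as a limit rather than a number. The expected step that the limit leaves unreadable from compound 3 to compound 4 is accordingly estimated to be no larger than the scatter.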

Compound 4, half-maximal cytotoxic concentration: > 20000 nM
Compound 4 ended at the assay's limit; the forecaster's own chance of this, stated with the estimate: 85%; the middle value lies beyond the limit too.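

For the compounds shown here, the result for compound 4 is again a limit of the assay and not a number, so no step between compound 4 and compound 1, compound 2 or compound 3 can be read in this assay at all: the limit of > 20000 nM in this assay, at which 4 of the 4 values shown sit. Going by these compounds, whether methylsulfanyl, butylsulfanyl, octylsulfanyl or cyclopentylamino on this aromatic carbon makes any difference in this assay stays open.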